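The compounds below may be only part of what the source reports. "The series", "measured", "known", "first", "only" and "open" are said of these compounds alone.

Measured in an in vitro ADME assay on microsomes from liver (Homo sapiens) for metabolic stability; a higher number here means faster removal of the compound, a lower number slower removal:
- Compound 1 `Cc1ccc(Cn2c(=O)[nH]c3c(N)nc(-c4ncco4)cc32)cn1`: < 7 mL.min-1.g-1 (a limit)
- Compound 2 `Cc1nc(Cn2c(=O)[nH]c3c(N)nc(C(F)(F)F)cc32)cs1`: < 7 mL.min-1.g-1 (a limit)
- Compound 3 `Nc1nc(C(F)(F)F)cc2c1[nH]c(=O)n2Cc1ccc(C(F)(F)F)nc1`: < 7 mL.min-1.g-1 (a limit)

Compound 3 stands at the same point as the other two compounds, and its entry is a limit and not a number. The set shares (the limit of < 7 mL.min-1.g-1 in this assay, at which 3 of the 3 values shown sit), so none of the three can be ranked against another. For the measured compounds named here, no two of them differ in one place only, which means that the data hold no measured step to serve as a guide.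

Compound 4 `Nc1nc(C(F)(F)F)cc2c1[nH]c(=O)n2Cc1ccc(NCC2CC2)nc1` keeps the core of compound 3 and changes one group: (cyclopropylmethyl)amino in place of trifluoromethyl on an aromatic carbon. The (cyclopropylmethyl)amino group takes the place of trifluoromethyl on an aromatic carbon, next to the ring nitrogen and para to a large group.

Going by the values given here, with no measured step available, the expectation rests on the structural change alone. Compound 3 gives < 7 mL.min-1.g-1, which is a limit, so any change that can be seen in this assay would have to be a rise. A moderate rise is expected, although compound 4 may also stay at the limit. The expected step is an at least 1.7-fold higher number from compound 3 to compound 4 (0.23 log units; that floor lies within the scatter). For compound 4 the estimated value is 12 mL.min-1.g-1, with an expected range from 7 mL.min-1.g-1 to 30 mL.min-1.g-1.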

Compound 4, intrinsic clearance in microsomes in the Homo sapiens assay: 121 mL.min-1.g-1
Estimate against measurement, compound 4: 10-fold (1.00 log units) below, and the stated range ends below it.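

For the compounds shown here, in the Homo sapiens assay compound 4 gives 121 mL.min-1.g-1 and the exchange of trifluoromethyl for (cyclopropylmethyl)amino gives an at least 17-fold higher number from compound 3 to compound 4 (1.23 log units; beyond the scatter) as the first step in this set that can be read, and it shows that the group on this aromatic carbon, next to the ring nitrogen and para to a large group, can move the number well beyond the scatter. Compound 4 is the only compound shown that leaves the shared limit, so the earlier entries gave no sign of how far the number could travel: the limit of < 7 mL.min-1.g-1 in the Homo sapiens assay, at which 3 of the 4 values shown sit.

In a physicochemical assay for lipophilicity, measured as octanol-water partition, at pH 7.4 (a higher number here means a more lipophilic compound, a lower number a more polar compound), compound 4 gives 3.2 and compound 3 gives "not determined" (no result reported) with no reported result, so no step can be read in that assay and the rise in clearance cannot be set against any change in lipophilicity.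

The compounds shown leave open which part of the entering group goes with the rise, the amino nitrogen with its hydrogen or the cyclopropylmethyl portion. Also open, as far as these compounds go, is whether a plain amine, a methoxy group or a longer open chain on this same carbon would stay at the limit or climb as far as compound 4 does.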